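Amide variation on a weak antiproliferative scaffold

This account rests on a few compounds, and the source may have more. Where it says the series, first, only, none or still open, it means among the compounds named here.

Compound 1 `Cn1cc(-c2nn(Cc3ccc(C(=O)N4CCCCC4)cc3)c(=O)c3ccccc23)cn1`: 73900 nM
Compound 2 `CN1CCC(NC(=O)c2ccc(Cn3nc(-c4cnn(C)c4)c4ccccc4c3=O)cc2)CC1`: 69500 nM

In a functional assay on HCT-116 cells (Homo sapiens) for antiproliferative activity, read by MTT assay, with a stated time of 72 h (a higher number here means a weaker inhibitor, a lower number a stronger inhibitor), compound 1 gives 73900 nM and compound 2 gives 69500 nM. The step of a 1.1-fold lower number from compound 1 to compound 2 (0.03 log units; within the scatter) lies within the scatter, so the two numbers sit together and neither compound can be ranked against the other; both are weak in this assay.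

Compound 3 `Cn1cc(-c2nn(Cc3ccc(C(=O)NC4CCCC4)cc3)c(=O)c3ccccc23)cn1` follows from compound 2 by cyclopentyl in place of 1-methylpiperidin-4-yl on an amide-type nitrogen. Among the measured compounds shown here, the only measured step that touches the same amide position is a 1.1-fold lower number from compound 1 to compound 2 (0.03 log units; within the scatter), and it did not move the number beyond the scatter. For the measured compounds named here, with one step of that size as the sole precedent, no shift beyond the scatter is expected for compound 3 in this assay, and the expected step is a 1.0-fold higher number from compound 2 to compound 3 (0.00 log units; within the scatter). For compound 3 the estimate in this assay is 70000 nM, with an expected range from 30000 nM to 160000 nM.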

Compound 3, half-maximal inhibitory concentration: 14300 nM
Beside the measured number, compound 3's estimate is 4.9-fold (0.69 log units) above it, and the stated range ends above it.
By their numbers in this assay, from the lowest: compound 3; then compounds 2 and 1 (each within the scatter of the next).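

The amide position is not flat in this assay after all. Among the compounds shown here, the change to cyclopentyl gives a 4.9-fold lower number from compound 2 to compound 3 (0.69 log units; beyond the scatter) and, against the tertiary amide, a 5.2-fold lower number from compound 1 to compound 3 (0.71 log units; beyond the scatter); both steps are modest, but they are the first beyond the scatter. Compound 2 and compound 3 both carry the amide hydrogen, so that hydrogen alone does not separate them, and no measurement at hand accounts for the shift.

Compound 3 changes ring size and removes the ring nitrogen with its methyl in a single step, so these two differences remain entangled; a cyclohexyl on the same amide-type nitrogen would separate them. Also open, as far as these compounds go, is whether the lower number depends on a ring at all or also holds for an open chain such as isopropyl.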